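The compounds below may be only part of what the source reports. "The series", "measured", "known", "first", "only" and "open" are said of these compounds alone.

Measured so far in a physicochemical assay for solubility, measured as kinetic solubility, with a stated time of 1 h, at pH 7.4; a higher number here means a more soluble compound, a lower number a less soluble compound:
- compound 1 `CC(=O)Nc1nc(-c2ccc(Cl)c(F)c2)cs1` gives 5000 nM 
- compound 2 `CC(=O)NC1=NN(c2ccc(Cl)c(Cl)c2)CC1` gives 31000 nM 

Of these two, compound 2 stands highest, with 31000 nM against the lower number of compound 1 at 5000 nM and a gap beyond the scatter of repeated measurements. Among the compounds with values here, the two compounds differ in more than one place, so their gap offers no single-change step to lean on.

Compound 3 `O=C(NC1=NN(c2ccc(Cl)c(Cl)c2)CC1)c1cccnc1` keeps the core of compound 2 and alters one place: pyridin-3-yl in place of methyl on a carbonyl carbon. Here pyridin-3-yl stands in place of methyl on a carbonyl carbon. Within the data shown here, no measured pair in this small set shows this change, so the expectation rests on the structural change alone, with a six-membered aromatic ring entering where a methyl stood. In this assay a moderate fall beyond the scatter is expected. The estimated step is a 3.9-fold lower number from compound 2 to compound 3 (0.59 log units; beyond the scatter) and it remains uncertain. Compound 3 is estimated at 8000 nM with an expected range from 2000 nM to 25000 nM in this measurement.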

Compound 3, solubility: 4000 nM
Beside the measured number, compound 3's estimate is 2.0-fold (0.30 log units) above it, and the stated range covers the measured number.
By their numbers in this assay, from the lowest: compounds 3 and 1 (each within the scatter of the next); then compound 2.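

In this assay, the carbonyl carbon whose other neighbour is an amide-type nitrogen now has a measured single change, with pyridin-3-yl in place of methyl giving a 7.8-fold lower number from compound 2 to compound 3 (0.89 log units; beyond the scatter) at that place. This shows that the number in this measurement responds to what this carbonyl carbon carries, since this one exchange moves it beyond the usual scatter while the rest of compound 2 stays the same. The entering group brings a six-membered aromatic ring and a hydrogen-bond acceptor together, and nothing given here accounts for the fall or assigns it to either feature.

The compounds shown leave open which part of the exchange goes with the lower number, since phenyl, ethyl or a longer chain at this carbonyl carbon would separate the ring, its nitrogen and the added atoms from one another. They also leave open whether a group carrying an amine or a carboxylic acid at the same place would give a number nearer to that of compound 2 or to that of compound 3.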